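From methoxy to cyano on the shared core

A few compounds are considered here, and "the series" means these few. Any claim that something is new, unique, unknown or untested is made for them only; others in the source may bear on it.

- compound 1 `COc1ccccc1S(=O)(=O)c1cccc(N)c1C#N`: 146000 nM
- compound 2 `N#Cc1c(N)cccc1S(=O)(=O)c1cccc2ccccc12`: > 200000 nM

Within the data shown here, in a functional assay on MT4 cells (Homo sapiens) for cytotoxicity (on this read-out higher numbers stand for weaker inhibition and lower numbers for stronger inhibition), compound 1 gives 146000 nM, and this is the only true number in the set. Compound 2 stands at > 200000 nM, which is a limit of the assay and not a number. With just these two readings, compound 1 cannot be placed in any wider range.

Compound 3 `N#Cc1ccccc1S(=O)(=O)c1cccc(N)c1C#N` keeps the core of compound 1 and carries cyano in place of methoxy on an aromatic carbon, ortho to a large group (cyano in place of methoxy on an aromatic carbon). Among the measured compounds shown here, no measured pair shows what such a change does. In this assay, therefore, no step beyond the usual scatter is expected, and neither direction is favoured. The expected change is a 1.0-fold higher number from compound 1 to compound 3 (0.01 log units; within the scatter). For compound 3 the estimated value is 150000 nM, with an expected range from 70000 nM to 200000 nM.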

Compound 3, half-maximal inhibitory concentration: > 200000 nM
Compound 3 ended at the assay's limit (the forecaster's own chance of this, stated with the estimate: 35%); at least 1.3-fold (0.12 log units) between middle value and limit.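

In this assay, compound 3 gives > 200000 nM, which is a limit of the assay and not a number. Cyano in place of methoxy on this aromatic carbon, ortho to a large group, gives the first step that can be read on the shared core, an at least 1.3-fold higher number from compound 1 to compound 3 (0.13 log units; that floor lies within the scatter), so only a floor is fixed and the true size of the step remains unknown. The result can say no more than this because the reading stops at the same ceiling as most of the set: the limit of > 200000 nM in this assay, at which 2 of the 3 values shown sit.

The compounds shown leave open how far the true value of compound 3 lies past its limit. They also leave open whether an amine, a carboxylic acid or a longer chain on this carbon would give a reading that differs from that of compound 1, which stands at 146000 nM.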